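Chloro to methyl on the aniline ring of compound 1

A few compounds are considered here, and "the series" means these few. Any claim that something is new, unique, unknown or untested is made for them only; others in the source may bear on it.

In a functional assay on U-87MG ATCC cells for antiproliferative activity against U-87 MG (Homo sapiens), read by spectrophotometry, with a stated time of 2 days (a higher number here means a weaker inhibitor of growth, a lower number a stronger inhibitor of growth), compound 1 (`Cc1ccc(Nc2ncc(C(F)(F)F)c(N3Cc4cccc(N(C)S(C)(=O)=O)c4C3)n2)c(Cl)c1`) gives > 30000 nM, and this is a limit of the assay, not a number. Among the compounds with values here, compound 2 (`CN(c1cccc2c1CN(c1nc(Nc3cccc(Oc4ccccc4)c3)ncc1C(F)(F)F)C2)S(C)(=O)=O`) gives 19500 nM in this assay, the only true number so far. Compound 3 (`Cc1ccc(Nc2ncc(C(F)(F)F)c(N3Cc4cccc(N(C)S(C)(=O)=O)c4C3)n2)c(C)c1`) carries methyl in place of chloro on an aromatic carbon, ortho to a large group and meta to a methyl group, turning 2-chloro-4-methylphenyl into 2,4-dimethylphenyl (methyl in place of chloro on an aromatic carbon). Within the data shown here, no measured pair tests this exchange, so no change beyond the scatter is expected in this assay, in either direction. The expectation rests on compound 1, which gives > 30000 nM, again a limit. The expected size is a number no higher from compound 1 to compound 3 (the limit leaves the size open). For compound 3 the estimated value is 30000 nM, with an expected range from 14000 nM to 60000 nM.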

Compound 3, concentration for 50% growth inhibition: > 30000 nM
Compound 3: a limit, no number; the forecaster's own chance of this, stated with the estimate: 60%; the middle value sits exactly at the limit.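

Compound 1 and compound 3 both end in a limit, so no step can be read between them: the limit of > 30000 nM in this assay, at which 2 of the 3 values shown sit.

On these data alone, whether 2-chloro-4-methylphenyl and 2,4-dimethylphenyl differ at all in growth inhibition remains open.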